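This account rests on a few compounds, and the source may have more. Where it says the series, first, only, none or still open, it means among the compounds named here.

Compound 1 `CC1=CC[C@@H]([C@@](C)(O)CCCC(C)(C)NC(=S)N/N=C\c2ccc(C)cc2)CC1` carries a 4-methylphenyl group on a carbon with a double bond to nitrogen. In a functional assay on OVCAR-3 cells (Homo sapiens) for cytotoxicity, read by sulforhodamine B assay (a higher number here means that more compound is tolerated, a lower number that less compound is tolerated), compound 1 gives 45300 nM, the lowest of the two numbers measured here, with compound 2 the closest to it. Compound 2 `CC1=CC[C@@H]([C@@](C)(O)CCCC(C)(C)NC(=S)N/N=C\c2ccc(O)cc2)CC1` gives 54400 nM in this assay, and the step of a 1.2-fold higher number from compound 1 to compound 2 (0.08 log units; within the scatter) shows that this exchange made no visible difference. Compound 3 `CC1=CC[C@@H]([C@@](C)(O)CCCC(C)(C)NC(=S)N/N=C\c2ccccc2Cl)CC1` reached only > 100000 nM, which is a limit of this assay and not a number. Compound 3 therefore sits at the limit of > 100000 nM in this assay, at which 1 of the 3 values shown sits, so the step of an at least 2.2-fold higher number from compound 1 to compound 3 (0.34 log units; beyond the scatter) has a floor only. Compound 4 `CC1=CC[C@@H]([C@@](C)(O)CCCC(C)(C)NC(=S)N/N=C\c2cccc(Cl)c2)CC1` has not been measured yet; it differs from compound 1 by 3-chlorophenyl in place of 4-methylphenyl on a carbon with a double bond to nitrogen. For the measured compounds named here, the only step that bears on it, the one to compound 3, went upward by at least a modest amount, so a similar or somewhat smaller upward step is expected, and the limit may well be reached again. For compound 4 a value of 75000 nM is expected, between 35000 nM and 160000 nM, which would mean an expected step of a 1.7-fold higher number from compound 1 to compound 4 (0.22 log units; within the scatter).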

Compound 4, concentration lethal to 50% of the cells: 48000 nM
Compound 4: the middle estimate sits 1.6-fold (0.19 log units) above what was measured; the measured number falls inside the stated range.
By their numbers in this assay, from the lowest: compounds 1, 4 and 2 (each within the scatter of the next). At a limit, above all of these: compound 3.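

In this assay, a chlorine on the ring does not by itself give the rise seen with compound 3: the change to 3-chlorophenyl gives a 1.1-fold higher number from compound 1 to compound 4 (0.03 log units; within the scatter), and the exchange for 4-hydroxyphenyl gives a 1.1-fold lower number from compound 2 to compound 4 (0.05 log units; within the scatter). Among these compounds, where the chlorine sits matters more than its presence, since 3-chlorophenyl in place of 2-chlorophenyl gives an at least 2.0-fold lower number from compound 3 to compound 4 (0.31 log units; beyond the scatter). The size of that step has a floor only, as the value of compound 3 is a limit and not a number: the limit of > 100000 nM in this assay, at which 1 of the 4 values shown sits.

On these data alone, it remains open whether 4-chlorophenyl would stay close to compound 4 or reach the limit like compound 3, and whether 2-methylphenyl would behave like the chlorine analogue. As far as these compounds go, how a phenyl ring bearing an amine or a carboxylic acid would behave at this position is also open.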